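The source may hold more compounds than are shown below. What is called first, only, known or untested is meant among the compounds shown, and "the series" means these compounds.

Compound 1 `Cc1ccc(/C=C2\Cc3ccccc3C2=O)cc1`: 59100 nM
Compound 2 `O=C1/C(=C/c2cccc(F)c2)CCc2ccccc21`: 61200 nM
Compound 3 `O=C1/C(=C/c2ccc(F)cc2)CCCc2ccccc21`: 60300 nM

All three compounds were measured in a functional assay on L1210 cells (Mus musculus) for inhibition; a lower number here means a stronger inhibitor, a higher number a weaker inhibitor. Compound 3, at 60300 nM, lies within the scatter of both compound 1 and compound 2, so the three cannot be ranked against one another.

The unmeasured compound 4 `O=C1/C(=C/c2ccc(Cl)cc2)CCCc2ccccc21` keeps the core of compound 3 and differs in one place: chloro in place of fluoro on an aromatic carbon. For the measured compounds named here, no measured pair shows this change directly, so the expectation rests only on how closely the three values sit, even though the compounds differ in substituent and core. Compound 1 gives 59100 nM and compound 2 gives 61200 nM.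

No step beyond the scatter is therefore expected in this assay. The expected step is a 1.2-fold lower number from compound 3 to compound 4 (0.08 log units; within the scatter). For compound 4 the estimated value is 50000 nM, with an expected range from 25000 nM to 100000 nM.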

Compound 4, half-maximal inhibitory concentration: 51800 nM
Estimate against measurement, compound 4: 1.0-fold (0.02 log units) below; the measured number falls inside the stated range.
By their numbers in this assay, from the lowest: compounds 4, 1, 3 and 2 (each within the scatter of the next).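

Chloro in place of fluoro on an aromatic carbon, para to a large group, gives a 1.2-fold lower number from compound 3 to compound 4 (0.07 log units; within the scatter) in this assay and is the first single change in this set that can be read directly. At this position on the core of compound 3, the two groups therefore cannot be told apart in this assay, as the step stays within the scatter. The data shown offer no measurement that would explain this result or bear on it.

Going by these compounds, whether a different kind of group at this position, such as an amine, a carboxylic acid or a methoxy group, would move the number beyond the scatter remains open. On these data alone, it also remains open whether the same exchange would give a similar step on the cores of compound 1 and compound 2.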